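The source may hold more compounds than are shown below. What is called first, only, known or untested is meant among the compounds shown, and "the series" means these compounds.

Among the compounds with values here, in a functional assay on PC-3 cells (Homo sapiens), read by MTT assay, with a stated time of 48 h (on this read-out higher numbers stand for weaker inhibition and lower numbers for stronger inhibition), compound 1 `CCN(CC)CCNC(=O)c1ccc(C(CC)(CC)c2ccc(OCC(=O)C(C)(C)C)c(C)c2)n1CC` gives 30 nM and compound 2 `CCn1c(C(=O)NCCN)ccc1C(CC)(CC)c1ccc(OCC(=O)C(C)(C)C)c(C)c1` gives 480 nM, the higher of the two numbers so far. Next comes compound 3 `CC[C@@H](C)[C@H](NC(=O)c1ccc(C(CC)(CC)c2ccc(OCC(=O)C(C)(C)C)c(C)c2)n1CC)C(=O)O`, with the change 1-carboxy-2-methylbutyl in place of 2-aminoethyl on an amide-type nitrogen. Within the data shown here, only one measured step bears on this chain, a 16-fold higher number from compound 1 to compound 2 (1.20 log units; beyond the scatter), and it is large, with amino in place of diethylamino. It shows that the end of this chain can move the number in this assay well beyond the scatter. Neither measured compound carries a carboxy group, however, so the data give no direction for the new group. No step beyond the scatter is expected, although the uncertainty is wide on both sides. The expected change is a 1.6-fold lower number from compound 2 to compound 3 (0.20 log units; within the scatter). Compound 3 is estimated at 300 nM, with an expected range of 30 nM to 2500 nM.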

Compound 3, half-maximal inhibitory concentration: 1600 nM
The estimate for compound 3 lay 5.3-fold (0.73 log units) below the measured number; low and high end bracket the measured number.
By their numbers in this assay, from the lowest: compound 1; then compound 2; then compound 3.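

In this assay, placing 1-carboxy-2-methylbutyl in place of 2-aminoethyl on the amide-type nitrogen gives a step beyond the scatter (a 3.3-fold higher number from compound 2 to compound 3 (0.52 log units; beyond the scatter)), so a carboxy-bearing chain at this position moves the number up rather than down. Measured against the 2-(diethylamino)ethyl chain, the same position shows a large step (a 53-fold higher number from compound 1 to compound 3 (1.73 log units; beyond the scatter)), and compound 1 stays lowest of the three, with its steps to both others beyond the scatter. No measurement at hand accounts for either step.

Compound 3 changes the end group and the carbon chain together, so the carboxy group cannot be separated from the branched chain or its 2 defined stereocentres. A methyl ester in place of the carboxylic acid, or a plain pentyl chain on the same nitrogen, would bear directly on that question.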